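A Thiophene in Place of a Morpholine

The compounds below may be only part of what the source reports. "The series", "measured", "known", "first", "only" and "open" are said of these compounds alone.

Measured in a functional assay on MCF7 cells (Homo sapiens) for cytotoxicity, read by MTT assay, with a stated time of 24 h; a lower number here means a stronger inhibitor, a higher number a weaker inhibitor:
Compound 1, `O=C(NC(=S)Nc1nc2cc([N+](=O)[O-])ccc2s1)N1CCOCC1`, gives 31000 nM.
Compound 2, `O=C(NC(=S)Nc1nc2ccccc2s1)N1CCOCC1`, gives 29300 nM.

Compound 1 stands highest of these two numbers, but its nearest neighbour, compound 2, sits a 1.1-fold lower number from compound 1 to compound 2 (0.02 log units; within the scatter), so the two are indistinguishable. Compound 3, `O=C(NC(=S)Nc1nc2cc([N+](=O)[O-])ccc2s1)c1cccs1`, differs from compound 1 by thiophen-2-yl in place of morpholin-4-yl on a carbonyl carbon. For the measured compounds named here, the only measured step, a 1.1-fold lower number from compound 1 to compound 2 (0.02 log units; within the scatter), changes the nitro group and says nothing about the carbonyl substituent, so no step bears on this change. Lacking such evidence, compound 3 is expected to move a 1.0-fold lower number from compound 1 to compound 3 (0.01 log units; within the scatter), that is, no step beyond the scatter. Compound 3 is therefore estimated at 30000 nM, in a range from 8000 nM to 110000 nM.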

Compound 3, half-maximal inhibitory concentration: 35900 nM
Compound 3: middle estimate off by 1.2-fold (0.08 log units), on the low side, and the stated range covers the measured number.
By their numbers in this assay, from the lowest: compounds 2, 1 and 3 (each within the scatter of the next).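

On the carbonyl carbon, thiophen-2-yl in place of morpholin-4-yl gives a 1.2-fold higher number from compound 1 to compound 3 (0.06 log units; within the scatter) in this assay. For the compounds shown here, this is the first look at that position, and a six-membered non-aromatic ring and a five-membered aromatic ring there leave the number within the scatter. Nothing at hand offers an explanation for this result.

On these data alone, whether a phenyl ring, a dimethylamine or a carboxylic acid on that carbonyl carbon would move the number beyond the scatter remains open. So does the effect of thiophen-2-yl on the core of compound 2, without the nitro group.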